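A few compounds are considered here, and "the series" means these few. Any claim that something is new, unique, unknown or untested is made for them only; others in the source may bear on it.

Notes on the series in a functional assay on SK-OV-3 cells (Homo sapiens) for antiproliferative activity, read by MTT assay, with a stated time of 72 h; on this read-out lower numbers stand for stronger inhibition and higher numbers for weaker inhibition. Compound 1 `O=C(CCc1cccc2c1B(O)OC2)Nc1cccc(-c2ccccc2)c1` gives 250 nM, compound 2 `O=C(CCc1cccc2c1B(O)OC2)Nc1cccc(-c2cccc(F)c2)c1` gives 480 nM, and compound 3 `O=C(CCc1cccc2c1B(O)OC2)Nc1cccc(-c2cccc(Cl)c2)c1` gives 300 nM, which lies within the scatter of both other values. Compound 4 `O=C(CCc1cccc2c1B(O)OC2)Nc1cccc(-c2cccc(OC(F)(F)F)c2)c1` has trifluoromethoxy in place of chloro on an aromatic carbon, meta to a large group: trifluoromethoxy in place of chloro on an aromatic carbon. The closest measured evidence is a 1.2-fold higher number from compound 1 to compound 3 (0.08 log units; within the scatter), a 1.9-fold higher number from compound 1 to compound 2 (0.28 log units; within the scatter) and a 1.6-fold lower number from compound 2 to compound 3 (0.20 log units; within the scatter), all within the scatter. Among the measured compounds shown here, no measured compound carries trifluoromethoxy, so this evidence is indirect. The expected change is none beyond the scatter, with a 1.3-fold higher number from compound 3 to compound 4 (0.10 log units; within the scatter) as the estimated step. For compound 4 the estimated value is 380 nM, with an expected range of 150 nM to 950 nM.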

Compound 4, half-maximal inhibitory concentration: 460 nM
Compound 4: the middle estimate sits 1.2-fold (0.08 log units) below what was measured; low and high end bracket the measured number.
By their numbers in this assay, from the lowest: compounds 1, 3, 4 and 2 (each within the scatter of the next).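

On an aromatic carbon meta to a large group, the larger trifluoromethoxy, with 5 heavy atoms and 1 hydrogen-bond acceptor, gives no step beyond the scatter against chloro (a 1.5-fold higher number from compound 3 to compound 4 (0.19 log units; within the scatter)), fluoro (a 1.0-fold lower number from compound 2 to compound 4 (0.02 log units; within the scatter)) or hydrogen (a 1.8-fold higher number from compound 1 to compound 4 (0.26 log units; within the scatter)). This place therefore accepts a group well beyond a single halogen atom without a measurable change in this series. No measurement shown offers an explanation for this result. From the compounds shown here alone, it remains open whether an amine or a carboxylic acid at this place would give a step beyond the scatter.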